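A few compounds are considered here, and "the series" means these few. Any claim that something is new, unique, unknown or untested is made for them only; others in the source may bear on it.

Measured compounds:
- Compound 1, `Cc1ccc(SCc2ccc(/C=C/C(=O)Nc3ccccc3N)cc2)cc1`: 48.3%
- Compound 2, `Nc1ccccc1NC(=O)c1ccc(CSc2nccc(C(F)(F)F)n2)cc1`: 95.1%
- Compound 3, `Cc1cc(C)cc(SCc2ccc(/C=C/C(=O)Nc3ccccc3N)cc2)c1`: 47.3%

The assay behind these numbers is a functional assay on A549 cells (Homo sapiens) for inhibition, read by CCK-8 assay, with a stated time of 72 h, tested at 8 uM; on this read-out higher numbers stand for more inhibition of growth at the one concentration tested and lower numbers for less inhibition of growth. Compound 3 stands lowest of the three values there, but its nearest neighbour is compound 1, and the step of a number 1 percentage points lower from compound 1 to compound 3 (within the scatter) shows that exchanging 3,5-dimethylphenyl for 4-methylphenyl on the sulfur left the read-out unmoved. Within the data shown here, compound 2 is a different matter: its value lies far above that of compound 3, though the two compounds differ in more than one place, so no single step can be drawn between them.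

Compound 4, `Nc1ccccc1NC(=O)/C=C/c1ccc(CSc2ccc(C(F)(F)F)cn2)cc1`, has not yet been measured. It differs from compound 3 by 5-(trifluoromethyl)pyridin-2-yl in place of 3,5-dimethylphenyl on a sulfur. Among the measured compounds shown here, the only measured step on this sulfur, from compound 1 to compound 3, concerns two methyl-substituted phenyl groups and was within the scatter, so it says little about a change to 5-(trifluoromethyl)pyridin-2-yl. For the measured compounds named here, the one compound carrying a trifluoromethyl-bearing heteroaryl on the sulfur, compound 2, is also the one with the high value, but its other differences prevent a clean attribution. Compound 4 is therefore expected to rise, with a step of a number 22.7 percentage points higher from compound 3 to compound 4 (beyond the scatter) carrying real uncertainty. The estimate for compound 4 is 70%, expected between 45% and 92%.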

Compound 4, percent growth inhibition at one concentration: 56.5%
Estimate against measurement, compound 4: 13.5 percentage points above; the range from low to high includes it.
By their numbers in this assay, from the lowest: compounds 3, 1 and 4 (each within the scatter of the next); then compound 2.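

In this assay, the change on the sulfur goes well beyond swapping methyl groups on a phenyl ring, since a ring with a nitrogen and a trifluoromethyl group replaces a ring of carbon only, yet the read-out gives a number 9.2 percentage points higher from compound 3 to compound 4 (within the scatter) and also a number 8.2 percentage points higher from compound 1 to compound 4 (within the scatter). At this one concentration, therefore, the 4-methylphenyl, 3,5-dimethylphenyl and 5-(trifluoromethyl)pyridin-2-yl groups on this sulfur cannot be told apart, even though the last brings a hetero atom, fluorine and a hydrogen-bond acceptor that the other two lack. No measurement at hand offers an explanation for this outcome.

Compound 2 differs from compound 4 in more than one place, so the compounds shown leave open how much of the high value of compound 2 belongs to the group on its sulfur and how much to the rest of its structure. They also leave open whether the read-out would stay in this range with a saturated chain bearing an amine or a carboxylic acid on the sulfur instead of an aromatic ring.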